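A Substituted Aryl Exchange on a Weakly Cytotoxic Core

This account rests on a few compounds, and the source may have more. Where it says the series, first, only, none or still open, it means among the compounds named here.

Compound 1 `O=C1C(=Cc2ccc(O)cc2)C(=O)N(c2ccc(Cl)cc2)N1c1ccc(Cl)cc1` is a weak inhibitor in a functional assay on MCF7 cells (Homo sapiens) for cytotoxicity, read by MTT assay, with a stated time of 72 h (a higher number here means a weaker inhibitor, a lower number a stronger inhibitor), where compound 1 gives 23200 nM. Compound 2 `O=C1C(=Cc2ccc(Cl)cc2)C(=O)N(c2ccc(Cl)cc2)N1c1ccc(Cl)cc1`, which carries chloro in place of hydroxy on an aromatic carbon, gives 28500 nM in this assay. The step of a 1.2-fold higher number from compound 1 to compound 2 (0.09 log units; within the scatter) lies within the scatter, so the two numbers cannot be told apart. Of the two numbers shown, compound 1 has the lower one, and compound 2 is its only neighbour.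

Compound 3 `COc1cccc(C=C2C(=O)N(c3ccc(Cl)cc3)N(c3ccc(Cl)cc3)C2=O)c1O` has not yet been measured in this assay. It differs from compound 1 in one place: 2-hydroxy-3-methoxyphenyl in place of 4-hydroxyphenyl on a double-bonded chain carbon bound to a double-bonded ring carbon. Among the compounds with values here, the single measured step, from compound 1 to compound 2, exchanged one group at this same place for another and moved the number by a 1.2-fold higher number from compound 1 to compound 2 (0.09 log units; within the scatter), no further than repeated measurements drift. Within the data shown here, nothing measured bears directly on the present exchange, so the only guide is that the one change tried at this place left the number where it was. The step of a 1.0-fold lower number from compound 1 to compound 3 (0.00 log units; within the scatter) is therefore expected to stay within the scatter. Compound 3 is expected to give about 23000 nM, most likely between 8000 nM and 65000 nM.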

Compound 3, half-maximal inhibitory concentration: 26700 nM
Beside the measured number, compound 3's estimate is 1.2-fold (0.06 log units) below it; low and high end bracket the measured number.
By their numbers in this assay, from the lowest: compounds 1, 3 and 2 (each within the scatter of the next).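

Compound 3 brings a bigger group to this place than the earlier pair did, with 2-hydroxy-3-methoxyphenyl at 9 heavy atoms against 7 for 4-hydroxyphenyl, and it adds a second oxygen, yet in this assay the step of a 1.2-fold higher number from compound 1 to compound 3 (0.06 log units; within the scatter) stays within the scatter. The step of a 1.1-fold lower number from compound 2 to compound 3 (0.03 log units; within the scatter) reads the same way, so the three groups tried on a double-bonded chain carbon bound to a double-bonded ring carbon give numbers that cannot be told apart, and a change in group size of this extent has left the read-out where it was. No other measurement is at hand that could explain this flat result.

On these data alone, all three groups are phenyl rings carrying only hydroxy, chloro or methoxy, so it remains open whether an amine, a carboxylic acid or a longer chain at this place would move the number beyond the scatter. As far as these compounds go, it also remains open whether a change elsewhere on the shared core, away from this place, would do so.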